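Swapping the aryl group on a weak antiproliferative compound

A few compounds are considered here, and "the series" means these few. Any claim that something is new, unique, unknown or untested is made for them only; others in the source may bear on it.

Values in a functional assay on HeLa cells (Homo sapiens) for antiproliferative activity, read by MTT assay, with a stated time of 72 h; a lower number here means a stronger inhibitor, a higher number a weaker inhibitor:
compound 1 `COc1cc(-c2ncnn2-c2ccc(Cl)cc2Cl)cc(OC)c1OC`: > 10000 nM
compound 2 `COc1cc(-n2ncnc2-c2ccc(Cl)cc2)cc(OC)c1OC`: > 10000 nM
compound 3 `CCOc1ccc(-c2ncnn2-c2cc(OC)c(OC)c(OC)c2)cc1Cl`: 6 nM

Compound 1 stands at the limit of > 10000 nM in this assay, at which 2 of the 3 values shown sit, which is a limit and not a measured number. Compound 2 also gives only a limit, > 10000 nM. Of the three, only compound 3 returns a number in this assay, 6 nM.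

The next compound, compound 4 `COc1cc(-c2ncnn2-c2ccc(N)cc2)cc(OC)c1OC`, keeps the core of compound 1 and carries 4-aminophenyl in place of 2,4-dichlorophenyl on an aromatic nitrogen. Within the data shown here, no measured pair isolates this change, so any forecast is uncertain. Compound 3 at 6 nM shows that strong values occur among these compounds, but it differs from compound 1 in more than one place. A shift towards a stronger inhibitor is therefore expected, though only a moderate one, and another limit remains possible. The expected change is an at least 5.0-fold lower number from compound 1 to compound 4 (0.69 log units; beyond the scatter). The estimate for compound 4 is 2000 nM, with an expected range from 150 nM to 10000 nM.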

Compound 4, half-maximal inhibitory concentration: > 10000 nM
Compound 4: only a limit was reported; the forecaster's own chance of this, stated with the estimate: 40%; middle value at least 5.0-fold (0.69 log units) away from the limit.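

In this assay compound 4 gives > 10000 nM, which is a limit and not a number. Compound 1 also gives only a limit, so no step can be read between compound 1 and compound 4. The compounds shown leave open whether any group in this place on the shared core returns a measurable value.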